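The source may report more compounds than this note shows. Statements on the series, on what has been measured and on what is new or still open speak of the compounds shown alone.

Working notes on the series.

Compound 1 `Nc1nc(=O)ccn1[C@@H]1O[C@H](COP(=O)(O)O)[C@@H](O)[C@H]1O` is the anchor of the set. In an in vitro functional assay on 1321-N1 cells for agonist activity at P2Y purinoceptor 2 (Homo sapiens), read by scintillation proximity assay and inositol phosphate accumulation (on this read-out lower numbers stand for an effect already at smaller amounts and higher numbers for an effect only at larger amounts of compound), compound 1 gives > 100000 nM, which is a limit of the assay and not a number. Compound 2 `CCSc1nc(=O)ccn1[C@@H]1O[C@H](COP(=O)(O)O)[C@@H](O)[C@H]1O` gives 1500 nM in this assay. Compound 3 `O=c1ccn([C@@H]2O[C@H](COP(=O)(O)O)[C@@H](O)[C@H]2O)c(SCc2ccccc2)n1` gives >= 100000 nM in this assay, again a limit and not a number. The measured steps all sit on the aromatic carbon of the core: an at least 66-fold lower number from compound 1 to compound 2 (1.82 log units; beyond the scatter), an at least 66-fold higher number from compound 2 to compound 3 (1.82 log units; beyond the scatter), while a step that the two limits leave unreadable from compound 1 to compound 3.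

Compound 4 `Nc1nc(=O)ccn1[C@@H]1O[C@H](COP(=O)(O)OP(=O)(O)O)[C@@H](O)[C@H]1O` is not yet measured. It differs from compound 1 by a group of 4 heavy atoms (3 oxygen, 1 phosphorus; no ring) in place of a hydrogen atom, on an oxygen. Among the compounds with values here, none of the measured steps touches this part of the molecule, so they give no direct guide to the size or direction of the step; the only footing is that compound 1 itself stands at a limit. The step is therefore expected to be an at least 1.2-fold lower number from compound 1 to compound 4 (0.09 log units; that floor lies within the scatter), with wide uncertainty. For compound 4 the expected value in this assay is 80000 nM, estimated within 15000 nM to 300000 nM, with a fair chance that only a limit is reported.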

Compound 4, half-maximal effective concentration: 604 nM
Beside the measured number, compound 4's estimate is 130-fold (2.12 log units) above it; the whole stated range lies above it.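

Within the data shown here, the step shows that this end of the molecule also governs the read-out, which the earlier steps, all on the aromatic carbon, could not show. In this assay, a group of 4 heavy atoms (3 oxygen, 1 phosphorus; no ring) in place of a hydrogen atom, on an oxygen whose other neighbours are phosphorus, gives an at least 160-fold lower number from compound 1 to compound 4 (2.21 log units; beyond the scatter), with the amino group kept unchanged. The true size of this step stays unknown, and only a floor can be read, because compound 1 stands at a limit: the limit of > 100000 nM in this assay, at which 1 of the 4 values shown sits.

The compounds shown leave open what the same change does with the ethylsulfanyl group of compound 2 or the benzylsulfanyl group of compound 3. Also open, from the compounds shown here alone, is how a triphosphate chain would compare with this group, or how a methylamino group would compare with the amino group.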